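Methyl added two bonds out from the aromatic carbon: series notes

The source may hold more compounds than are shown below. What is called first, only, known or untested is meant among the compounds shown, and "the series" means these compounds.

Measured in a functional assay on MCF7 cells (Homo sapiens) for cytotoxicity, read by sulforhodamine B assay, with a stated time of 48 h; a lower number here means a stronger inhibitor, a higher number a weaker inhibitor:
compound 1 `CCc1ccccc1NS(=O)(=O)c1cccc(NC(=O)NCCCCl)c1`: 43000 nM
compound 2 `CCCc1ccccc1NS(=O)(=O)c1cccc(NC(=O)NCCCCl)c1`: 18000 nM
compound 3 `CCNC(=O)Nc1ccc(S(=O)(=O)Nc2ccccc2CC)cc1`: 91000 nM

Compound 1 and compound 2 share a core and differ in one place, (methyl in place of hydrogen on a saturated chain carbon, two bonds along the chain from an aromatic carbon). In this assay this gave a 2.4-fold lower number from compound 1 to compound 2 (0.38 log units; beyond the scatter), a step that clears the usual scatter of repeats but is modest in size. Compound 3 gives the highest number of the three; its values stand beyond the scatter from both compound 1 and compound 2. The difference between the core of compound 3 and the core of compound 1 is not broken down here.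

Compound 4 `CCCc1ccccc1NS(=O)(=O)c1ccc(NC(=O)NCC)cc1` is not yet measured. For the measured compounds named here, it differs from compound 3 by methyl in place of hydrogen on a saturated chain carbon, two bonds along the chain from an aromatic carbon, which is the same change as the one from compound 1 to compound 2, at a place described in the same words. Going by the values given here, the only precedent for this change is the single step from compound 1 to compound 2, on a different core, so the expectation rests on that one step and on the value of compound 3.

Compound 4 is expected to give about 40000 nM in this assay, because compound 3 gives 91000 nM and the same change once gave a 2.4-fold lower number from compound 1 to compound 2 (0.38 log units; beyond the scatter). That expectation means a step of a 2.3-fold lower number from compound 3 to compound 4 (0.36 log units; beyond the scatter). Given that a single precedent is a thin basis, compound 4 is estimated to fall between 18000 nM and 90000 nM.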

Compound 4, half-maximal inhibitory concentration: 37000 nM
Compound 4: the middle estimate sits 1.1-fold (0.03 log units) above what was measured; low and high end bracket the measured number.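

In this assay, methyl in place of hydrogen on a saturated chain carbon, two bonds along the chain from an aromatic carbon, gives a 2.5-fold lower number from compound 3 to compound 4 (0.39 log units; beyond the scatter), and the step on this second core matches the earlier one: the same change on two cores in this assay, a 2.4-fold lower number (0.38 log units; beyond the scatter) from compound 1 to compound 2 and a 2.5-fold lower number (0.39 log units; beyond the scatter) from compound 3 to compound 4, 1.0-fold (0.01 log units) apart, within the scatter of two such steps

Within this series, the ethyl to propyl change therefore carries from the core of compound 1 to the core of compound 3 with its modest size intact, so the step seen on one core was a usable guide on the other. For the compounds shown here, this rests on only two pairs, two cores and one assay; it does not show that the step would hold on a further core, and it gives no reason for the lower number on either core.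

A longer chain such as butyl, or an amine or a carboxylic acid in place of the propyl group, remains open, so the compounds shown do not tell whether the trend continues past propyl or how far it extends. Also open is how much each of the differences between the two cores contributes, since those differences are not separated by any pair shown here.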